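Benzamide ring variation on the shared core: toward compound 4

The source may hold more compounds than are shown below. What is called first, only, known or untested is meant among the compounds shown, and "the series" means these compounds.

Measured in a functional assay on MCF7 cells (Homo sapiens) for antiproliferative activity, read by CCK-8 assay, with a stated time of 72 h; a higher number here means a weaker inhibitor, a lower number a stronger inhibitor:
compound 1 `COc1cc(C(=O)Nc2ccc(C(=O)/C=C/c3nc(C)c(C)nc3C)cc2)cc(OC)c1OC` gives 2760 nM
compound 2 `COc1ccc(C(=O)Nc2ccc(C(=O)/C=C/c3nc(C)c(C)nc3C)cc2)cc1OC` gives 1660 nM
compound 3 `COc1cccc(OC)c1C(=O)Nc1ccc(C(=O)/C=C/c2nc(C)c(C)nc2C)cc1` gives 2470 nM

Compound 2 is the reference point. Its separation from the other two is small: a 1.7-fold lower number from compound 1 to compound 2 (0.22 log units; within the scatter) and a 1.5-fold higher number from compound 2 to compound 3 (0.17 log units; within the scatter) both stay within the scatter, so the three measured compounds are not told apart in this assay.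

Compound 4 `Cc1nc(C)c(/C=C/C(=O)c2ccc(NC(=O)c3ccccc3)cc2)nc1C` is the next step from compound 2: phenyl in place of 3,4-dimethoxyphenyl on a carbonyl carbon. Going by the values given here, two measured steps bear on it. In the step of a 1.7-fold lower number from compound 1 to compound 2 (0.22 log units; within the scatter) a hydrogen replaced a methoxy on an aromatic carbon without a shift beyond the scatter, and in the step of a 1.5-fold higher number from compound 2 to compound 3 (0.17 log units; within the scatter) a 2,6-dimethoxyphenyl replaced a 3,4-dimethoxyphenyl on the carbonyl carbon, again within the scatter. Among the compounds with values here, compound 4 removes both remaining methoxy groups from that ring; no measured compound carries a bare phenyl there, so the expectation rests only on the indifference seen so far.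

Compound 4 is expected to land near compound 2, with a 1.5-fold higher number from compound 2 to compound 4 (0.18 log units; within the scatter) expected to stay within the scatter or only just beyond it, leaning toward a higher number. Compound 4 is therefore estimated at 2500 nM, with a range of 1000 nM to 6500 nM.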

Compound 4, half-maximal inhibitory concentration: 990 nM
Beside the measured number, compound 4's estimate is 2.5-fold (0.40 log units) above it; the measured number lies below the stated range.
By their numbers in this assay, from the lowest: compounds 4, 2, 3 and 1 (each within the scatter of the next, the first and the last beyond it).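

In this assay, going by these compounds alone, the bare phenyl on the carbonyl carbon gives the first step in this set that lies beyond the scatter, though a modest one: a 2.5-fold lower number from compound 3 to compound 4 (0.40 log units; beyond the scatter), with phenyl in place of 2,6-dimethoxyphenyl. Set against 3,4-dimethoxyphenyl, the same change stays within the scatter, a 1.7-fold lower number from compound 2 to compound 4 (0.22 log units; within the scatter), so at this place the methoxy groups can all be removed with no loss of activity, and only the comparison with the 2,6-dimethoxyphenyl compound separates. No available evidence accounts for this difference between the two steps.

Still open, from the compounds shown here alone, is whether any group on this phenyl ring improves on the bare ring, for example an amine, a carboxylic acid or a single chlorine. A phenyl carrying one methoxy group alone also remains untested among the compounds shown, so the contribution of each methoxy group cannot be separated.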